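Cyano in Place of Methyl: Expecting the Next Value

This account rests on a few compounds, and the source may have more. Where it says the series, first, only, none or still open, it means among the compounds named here.

Measured compounds:
- compound 1, `O=c1c2c(ccn1[C@@H]1O[C@H](COP(=O)(O)OP(=O)(O)OP(=O)(O)O)[C@@H](O)[C@H]1O)CCCC2`: 55 nM
- compound 2, `O=c1c2ccsc2ccn1[C@@H]1O[C@H](COP(=O)(O)OP(=O)(O)OP(=O)(O)O)[C@@H](O)[C@H]1O`: 30 nM
- compound 3, `Cc1ccc2c(=O)n([C@@H]3O[C@H](COP(=O)(O)OP(=O)(O)OP(=O)(O)O)[C@@H](O)[C@H]3O)ccc2c1`: 35 nM

All three share a triphosphate-bearing sugar attached to a fused bicyclic core and were tested in a functional assay for agonist activity at P2Y purinoceptor 2 (Homo sapiens), read by FLIPR; a lower number here means that less compound is needed, a higher number that more compound is needed for the effect. In this assay compound 1 gives 55 nM, compound 2 gives 30 nM, and compound 3 gives 35 nM. Among these three numbers compound 3 stands second highest; its nearest neighbour is compound 2 and its furthest is compound 1, but both gaps lie within the usual scatter, so no ordering of the three can be claimed.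

Compound 4, `N#Cc1ccc2c(=O)n([C@@H]3O[C@H](COP(=O)(O)OP(=O)(O)OP(=O)(O)O)[C@@H](O)[C@H]3O)ccc2c1`, differs from compound 3 in a single place: cyano in place of methyl on an aromatic carbon. In words, a cyano group replaces a methyl group on an aromatic carbon of the fused core. Going by the values given here, no measured pair shows this particular swap, so there is no step to lean on. Given how little the three measured values move from one another, the expected step for this change is small, in either direction or none beyond the scatter, with a slight lean toward a higher number. Compound 4 is therefore estimated at 50 nM, with a range from 15 nM to 170 nM. That estimate corresponds to an expected step of a 1.4-fold higher number from compound 3 to compound 4 (0.15 log units; within the scatter).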

Compound 4, half-maximal effective concentration: 88 nM
Compound 4: the middle estimate sits 1.8-fold (0.25 log units) below what was measured; measured number inside the range.
By their numbers in this assay, from the lowest: compounds 2, 3, 1 and 4 (each within the scatter of the next, the first and the last beyond it).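

In this assay, going by these compounds alone, the change from methyl to cyano on this aromatic carbon gives a 2.5-fold higher number from compound 3 to compound 4 (0.40 log units; beyond the scatter) and is the first single-place change that can be read directly, as the earlier compounds differ from one another in more than one place. It shows that this position is not indifferent to the group it carries: exchanging a single small substituent, with the rest of the molecule untouched, is enough to move the number beyond the usual scatter, though only modestly. Nothing in the data shown explains why this swap moves the number in this direction.

One pair gives one step at one position, so it cannot say whether the trend depends on the nitrile itself or would also appear with other groups on the same carbon, such as an amine, a carboxylic acid, a methoxy group, a chlorine atom or plain hydrogen. It also leaves open whether the same swap would produce a step of similar size on a different core, such as the core of compound 1 or compound 2, or at another carbon of this ring.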